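A few compounds are considered here, and "the series" means these few. Any claim that something is new, unique, unknown or untested is made for them only; others in the source may bear on it.

Measured in an ADME assay on microsomes from liver (Homo sapiens) for metabolic stability, read by LC-MS, using NADPH, with stated times of 6 min and 10 min, tested at 0.5 uM; on this read-out lower numbers stand for a less stable compound and higher numbers for a more stable compound:
- compound 1 `CC(=O)N1CCN(c2cc(-c3cc(Cl)c4c(N)ncnn34)ccc2Cl)C(=O)C1(C)C`: 85%
- compound 2 `CC(=O)N1CCN(c2cc(-c3cc(Cl)c4c(N)ncnn34)ccc2C(C)O)C(=O)C1(C)C`: 100%

Among the compounds with values here, compound 2, at 100%, stands highest of the two, and compound 1 is its only neighbour on these numbers. The next structure is compound 3 `CC(=O)N1CCN(c2cc(-c3cc(Cl)c4c(N)ncnn34)ccc2C#N)C(=O)C1(C)C`, which has not yet been measured. It differs from compound 2 as follows: cyano in place of 1-hydroxyethyl on an aromatic carbon. This is cyano in place of 1-hydroxyethyl on an aromatic carbon, ortho to a large group and para to a large group.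

Within the data shown here, no measured compound carries cyano, so the data hold no direct precedent for it. Among the measured compounds shown here, one measured step bears on this place in the structure, where chloro gave way to 1-hydroxyethyl: a number 15 percentage points higher from compound 1 to compound 2 (beyond the scatter). That step is modest but beyond the scatter. Compound 3 gives up the same 1-hydroxyethyl, so a fall of comparable modest size is expected, though the size remains uncertain. The estimated step is a number 12 percentage points lower from compound 2 to compound 3 (beyond the scatter). For compound 3 the expected value is 88%, with an estimated range from 72% to 100%.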

Compound 3, percent of the compound remaining: 90%
Estimate against measurement, compound 3: 2 percentage points below, within the range that was stated.
By their numbers in this assay, from the lowest: compounds 1, 3 and 2 (each within the scatter of the next, the first and the last beyond it).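

In this assay, cyano in place of 1-hydroxyethyl gives a number 10 percentage points lower from compound 2 to compound 3 (within the scatter), and cyano in place of chloro gives a number 5 percentage points higher from compound 1 to compound 3 (within the scatter). Cyano therefore cannot be separated from either of the other two groups at this aromatic carbon, although those two groups are separated from each other by a number 15 percentage points higher from compound 1 to compound 2 (beyond the scatter), so a group without a hydrogen-bond donor is not set apart from 1-hydroxyethyl on these numbers. No measurement at hand offers an explanation for these results.

The compounds shown leave open how an amine, a carboxylic acid or a plain ethyl chain on this aromatic carbon would stand in this assay, and so whether the higher number of compound 2 goes with the hydroxyl of 1-hydroxyethyl or with its carbon chain. They also leave open whether the gap between chloro and 1-hydroxyethyl would hold on a core other than the shared one.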